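From 3,4-Dimethoxyphenyl to 3-Fluorophenyl on an Amine Nitrogen

The source may hold more compounds than are shown below. What is called first, only, known or untested is meant among the compounds shown, and "the series" means these compounds.

The measured compounds:
compound 1 `C=C1[C@@H](C/C=C2/C(=O)OC[C@H]2OC(C)=O)[C@]2(C)CC[C@@H](OC(C)=O)[C@@](C)(CO[Si](C)(C)C(C)(C)C)[C@H]2C[C@@H]1O`: 9310 nM
compound 2 `C=C1[C@@H](OC(C)=O)C[C@@H]2[C@](C)(COC=O)[C@H](OC(C)=O)CC[C@@]2(C)[C@@H]1C[C@@H](Nc1ccc(OC)c(OC)c1)C1=CCOC1=O`: 42800 nM
compound 3 `C=C1CC[C@@H]2[C@](C)(CO[Si](C)(C)C(C)(C)C)[C@H](OC(C)=O)CC[C@@]2(C)[C@@H]1C/C=C1/C(=O)OC[C@H]1OC(C)=O`: 4690 nM

In a functional assay on HT-29 cells (Homo sapiens) for cytotoxicity, read by sulforhodamine B assay (on this read-out lower numbers stand for stronger inhibition and higher numbers for weaker inhibition), compound 2 gives the highest of the three numbers, so it is the weakest of the three on this read-out. Compound 1 gives 9310 nM and compound 3 gives 4690 nM, both well clear of compound 2.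

Going by the values given here, the only step between two measured compounds is a 2.0-fold lower number from compound 1 to compound 3 (0.30 log units; within the scatter); it changes a saturated ring carbon far from the amine and lies within the scatter, so it tells little about what follows.

Compound 4 `C=C1[C@@H](OC(C)=O)C[C@@H]2[C@](C)(COC=O)[C@H](OC(C)=O)CC[C@@]2(C)[C@@H]1C[C@@H](Nc1cccc(F)c1)C1=CCOC1=O` differs from compound 2 at the amine nitrogen: 3-fluorophenyl in place of 3,4-dimethoxyphenyl on an amine nitrogen. Among the compounds with values here, no measured pair changes this group, so nothing recorded here bears directly on the step. With no guide, the expectation is a step of a 1.1-fold lower number from compound 2 to compound 4 (0.03 log units; within the scatter), that is, none beyond the scatter, and a wide range. Compound 4 is therefore estimated at 40000 nM, between 12000 nM and 130000 nM.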

Compound 4, half-maximal inhibitory concentration: 9410 nM
Compound 4: middle estimate off by 4.3-fold (0.63 log units), on the high side; the whole stated range lies above it.
By their numbers in this assay, from the lowest: compounds 3, 1 and 4 (each within the scatter of the next); then compound 2.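

In this assay, 3-fluorophenyl in place of 3,4-dimethoxyphenyl on the amine nitrogen gives a 4.5-fold lower number from compound 2 to compound 4 (0.66 log units; beyond the scatter), a step beyond the scatter. Going by these compounds alone, this is the first sign that the number responds to the aryl group at this position, which no earlier pair of compounds changed. The change swaps 10 heavy atoms for 7 and 2 hydrogen-bond acceptors for 0, but nothing shown here explains the step.

The loss of the two methoxy groups and the gain of the fluorine happen in a single step, so it remains open which of them accounts for the shift. An unsubstituted phenyl or a 3-methoxyphenyl on the same nitrogen would help separate the two, and whether the trend extends to other groups at this position is also unknown.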